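Amide for amine on a fused ring nitrogen

The source may hold more compounds than are shown below. What is called first, only, known or untested is meant among the compounds shown, and "the series" means these compounds.

Measured compounds:
compound 1 `Cc1cccc(C#Cc2nc3c(s2)C(=O)NCC3)c1`, in an assay on HEK293 cells for negative allosteric modulation of metabotropic glutamate receptor 5 (Homo sapiens), read by FLIPR, with a stated time of 1 h (on this read-out higher numbers stand for weaker inhibition and lower numbers for stronger inhibition), a limit of > 10000 nM
compound 2 `CCN1CCc2nc(C#Cc3ccccc3)sc2C1`, in this assay 1200 nM
compound 3 `Fc1cccc(C#Cc2nc3c(s2)CN(C2CCOC2)CC3)c1`, in this assay compound 3 gives 400 nM.

For compound 1 the entry in this assay is a limit of the assay and not a number, as described in the limit of > 10000 nM in this assay, at which 1 of the 3 values shown sits. Among the two numbers that were obtained, compound 2 stands at the higher one, and compound 3 at the lower one, a gap beyond the usual scatter; the two differ in more than one place, so no single step can be read from them.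

Compound 4 `CCC(=O)N1CCc2nc(C#Cc3ccccc3)sc2C1` is not yet measured. It differs from compound 2 by propanoyl in place of ethyl on an amine nitrogen in a ring. Within the data shown here, no measured pair isolates this kind of change, so the size of the step rests on judgement alone. Among the measured compounds shown here, the only carbonyl-bearing compound in the set, compound 1, returned a limit rather than a number, but its carbonyl sits in a different arrangement, so it does not settle the question. A step from compound 2 to compound 4 towards weaker inhibition, a 2.9-fold higher number from compound 2 to compound 4 (0.46 log units; beyond the scatter), is expected, of moderate size. For compound 4 the expected value in this assay is 3500 nM, within 900 nM to 12000 nM.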

Compound 4, half-maximal inhibitory concentration: 38 nM
Compound 4: the middle estimate sits 92-fold (1.96 log units) above what was measured, outside the stated range (below it).
By their numbers in this assay, from the lowest: compound 4; then compound 3; then compound 2. At a limit, above all of these: compound 1.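

In this assay, propanoyl in place of ethyl on an amine nitrogen in a ring gives a 32-fold lower number from compound 2 to compound 4 (1.50 log units; beyond the scatter), a large step and the first in the set that can be read at a single place. It shows that the group on this nitrogen alone can shift the number strongly, and that the nitrogen need not remain an amine for inhibition to be retained and strengthened, something compound 2 and compound 3 could not show, as they differ in more than one place. Compound 1 also carries a carbonyl, but in a different arrangement, and its entry is a limit and not a number, so it offers no comparison: the limit of > 10000 nM in this assay, at which 1 of the 4 values shown sits.

The step brings in a carbonyl and a longer chain together, so the compounds shown do not separate the two, and neither a propyl group nor an acetyl group on this nitrogen is among them to tell which part matters. As far as these compounds go, whether the same change would give a step of similar size with the fluorine-bearing aromatic ring of compound 3 also remains open.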